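A few compounds are considered here, and "the series" means these few. Any claim that something is new, unique, unknown or untested is made for them only; others in the source may bear on it.

Measured so far:
- compound 1 `CCOC(=O)/C(=C/c1ccccc1)CN1C(=O)[C@@H](OC)[C@H]1c1ccc(Cl)cc1`, which in a functional assay on MDA-MB-231 cells (Homo sapiens) for antiproliferative activity, read by MTT assay, with a stated time of 48 h (on this read-out lower numbers stand for stronger inhibition and higher numbers for weaker inhibition), gives 11100 nM
- compound 2 `CCOC(=O)/C(=C/c1ccccc1)CN1C(=O)[C@@H](OC)[C@H]1c1cccc([N+](=O)[O-])c1`, which in this assay gives 14400 nM
- compound 3 `COC(=O)/C(=C/c1ccccc1)CN1C(=O)[C@@H](OC)[C@H]1c1cccc(C(F)(F)F)c1`, which in this assay gives 18200 nM

Compound 3 carries the highest of the three numbers, yet its distance to compound 2 and to compound 1 is in each case within the scatter, so the three compounds cannot be told apart on these data. Among the compounds with values here, the one step that changes the aryl group on the saturated ring carbon, a 1.3-fold higher number from compound 1 to compound 2 (0.11 log units; within the scatter), also stays within the scatter.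

Compound 4 `COC(=O)/C(=C/c1ccccc1)CN1C(=O)[C@@H](OC)[C@H]1c1ccccc1` differs from compound 3 in one place: hydrogen in place of trifluoromethyl on an aromatic carbon. Cut one bond further out, this reads 3-(trifluoromethyl)phenyl to phenyl. Within the data shown here, the only comparable evidence is the aryl change from compound 1 to compound 2, which left the number essentially unmoved, so no step beyond the scatter is expected in this assay in either direction. Compound 4 is therefore estimated at 17000 nM, within a range from 8000 nM to 40000 nM, which amounts to an expected step of a 1.1-fold lower number from compound 3 to compound 4 (0.03 log units; within the scatter).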

Compound 4, half-maximal inhibitory concentration: 11100 nM
The estimate for compound 4 lay 1.5-fold (0.19 log units) above the measured number, within the range that was stated.
By their numbers in this assay, from the lowest: compounds 1, 4, 2 and 3 (each within the scatter of the next).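

Replacing trifluoromethyl with hydrogen on this aromatic carbon gives a 1.6-fold lower number from compound 3 to compound 4 (0.21 log units; within the scatter) in this assay, so this change does not separate the two compounds. The earlier compounds shown here all carry a group on this aryl ring, whereas compound 4 has a plain phenyl and still cannot be told apart from compound 3, so on these data the trifluoromethyl group is not required for the activity seen in compound 3. No other measurement bears on this result.

Going by these compounds, it remains open whether an amine, a carboxylic acid or a longer alkyl chain on this aromatic carbon would move the number beyond the scatter. On these data alone, it is also open whether the plain phenyl would give a similar number with the ethyl ester of compound 1 in place of the methyl ester.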